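This account rests on a few compounds, and the source may have more. Where it says the series, first, only, none or still open, it means among the compounds named here.

Compound 1, `CN(C)CCn1cnnc1-c1cc(Oc2ccc(NC(=O)N/N=C/c3ccc(F)cc3)cc2F)ccn1`, in an ADME assay on WI-38 cells (Homo sapiens) for cytotoxicity, read by MTT assay, with a stated time of 72 h (on this read-out lower numbers stand for stronger inhibition and higher numbers for weaker inhibition), gives 3980 nM.
Compound 2, `CN(C)CCn1cnnc1-c1cc(Oc2ccc(NC(=O)N/N=C/c3ccc(F)cc3F)cc2F)ccn1`, in this assay gives 5030 nM.

Among these two numbers compound 2 holds the higher one, but its only neighbour is compound 1, and the step of a 1.3-fold higher number from compound 1 to compound 2 (0.10 log units; within the scatter) lies within the scatter, so the two are not told apart. Compound 3, `CN(C)CCn1cnnc1-c1cc(Oc2ccc(NC(=O)N/N=C/c3cccc(Br)c3)cc2F)ccn1`, arises from compound 2 by a change at the same part of the molecule: 3-bromophenyl in place of 2,4-difluorophenyl on a carbon with a double bond to nitrogen. Going by the values given here, the one measured step, a 1.3-fold higher number from compound 1 to compound 2 (0.10 log units; within the scatter), changed this aryl group by a single fluoro and left the number essentially unmoved. An exchange of the whole aryl group is a larger change, yet nothing measured points in either direction. The expected step is therefore a 1.1-fold lower number from compound 2 to compound 3 (0.05 log units; within the scatter), no more than the scatter. Compound 3 is expected at 4500 nM, in the range 1800 nM to 11000 nM.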

Compound 3, half-maximal inhibitory concentration: 4230 nM
For compound 3 the middle estimate is 1.1-fold (0.03 log units) above the measured one, and the stated range covers the measured number.
By their numbers in this assay, from the lowest: compounds 1, 3 and 2 (each within the scatter of the next).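

Where the earlier pair differed by a single fluoro, this step exchanges the whole aryl group, and a different halogen with it: 3-bromophenyl in place of 2,4-difluorophenyl on a carbon with a double bond to nitrogen comes to a 1.2-fold lower number from compound 2 to compound 3 (0.08 log units; within the scatter) in this assay. Set against the singly fluorinated compound, 3-bromophenyl in place of 4-fluorophenyl comes to a 1.1-fold higher number from compound 1 to compound 3 (0.03 log units; within the scatter) and the three compounds cannot be told apart at this position. Nothing at hand explains why these numbers stay so close.

On these data alone, all three compounds carry a halogen on the phenyl ring here, so it stays open whether a phenyl bearing an amine or a carboxylic acid would also stay in this range. The rest of the molecule is the same throughout, so the effect of a change elsewhere, such as a longer chain on the shared core, is also unknown.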